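The source may hold more compounds than are shown below. What is called first, only, known or untested is meant among the compounds shown, and "the series" means these compounds.

- compound 1 `COc1cc(/C=C2\CN(S(C)(=O)=O)C=CC2=O)cc(OC)c1OC` gives 15900 nM
- compound 2 `COc1cc(/C=C2\CN(S(=O)(=O)c3ccccc3)C=CC2=O)cc(OC)c1OC` gives 23300 nM
- compound 3 `COc1cc(/C=C2\CN(S(=O)(=O)c3ccc(C)cc3)C=CC2=O)cc(OC)c1OC` has not yet been measured

In a functional assay on MDA-MB-231 cells (Homo sapiens) for antiproliferative activity, read by sulforhodamine B assay, with a stated time of 72 h (on this read-out lower numbers stand for stronger inhibition and higher numbers for weaker inhibition), compound 2 gives 23300 nM and lies within the scatter of compound 1 (15900 nM), so the two cannot be told apart. Compound 3 differs from compound 2 in one place (methyl in place of hydrogen on an aromatic carbon): methyl in place of hydrogen on an aromatic carbon, para to a large group, which turns phenyl into 4-methylphenyl. Within the data shown here, the one measured step that bears on this, phenyl in place of methyl on a sulfonyl sulfur (a 1.5-fold higher number from compound 1 to compound 2 (0.17 log units; within the scatter)), stayed within the scatter. No step beyond the scatter is therefore expected in this assay for compound 3, and no direction can be named. The expected change is modest (a 1.2-fold lower number from compound 2 to compound 3 (0.07 log units; within the scatter)). The estimate for compound 3 is 20000 nM, with an expected range from 9000 nM to (42000 nM).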

Compound 3, half-maximal inhibitory concentration: 22200 nM
Compound 3: the middle estimate sits 1.1-fold (0.05 log units) below what was measured, and the stated range covers the measured number.
By their numbers in this assay, from the lowest: compounds 1, 3 and 2 (each within the scatter of the next).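

In this assay methyl in place of hydrogen on an aromatic carbon, para to a large group, gives a 1.0-fold lower number from compound 2 to compound 3 (0.02 log units; within the scatter) and so adds a carbon at this position with no change that can be told from the scatter. Replacing the methyl on the sulfonyl sulfur with 4-methylphenyl gives a 1.4-fold higher number from compound 1 to compound 3 (0.14 log units; within the scatter) and likewise stays inside the scatter, which extends the flat picture from phenyl to a substituted phenyl. Nothing measured here offers an explanation for this result.

The compounds shown leave open whether a group unlike methyl at this ring position, such as an amine or a carboxylic acid, would move the number beyond the scatter. As far as these compounds go, it also remains unknown whether any change on the sulfonyl group can shift the number in this assay at all.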